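Replacing a hydroxyphenyl with a methylphenyl on the hydrazone carbon

The source may report more compounds than this note shows. Statements on the series, on what has been measured and on what is new or still open speak of the compounds shown alone.

Measured compounds:
compound 1 `COc1ccc(/C(=N\NC(=O)Nc2nnc(COc3ccc4ccccc4c3)o2)c2ccccc2)cc1`: 300 mg/kg
compound 2 `C/C(=N/NC(=O)Nc1nnc(COc2ccc3ccccc3c2)o1)c1ccc(N)cc1`: 300 mg/kg
compound 3 `O=C(N/N=C\c1cccc(O)c1)Nc1nnc(COc2ccc3ccccc3c2)o1`: 300 mg/kg

In a functional assay on the whole organism (strain Swiss albino) with Mus musculus as the target, in the maximal electroshock model, with a stated time of 4 h (a higher number here means that more compound is needed for the effect, a lower number that less compound is needed), compound 1 gives 300 mg/kg, compound 2 gives 300 mg/kg and compound 3 gives 300 mg/kg, so compound 3 stands level with compounds 1 and 2. Among the measured compounds shown here, the one step between neighbours, no change at the digits printed from compound 2 to compound 3 (within the scatter), left the minimum effective dose unchanged within the scatter. Compound 4 `Cc1ccc(/C=N\NC(=O)Nc2nnc(COc3ccc4ccccc4c3)o2)cc1` differs from compound 3 by 4-methylphenyl in place of 3-hydroxyphenyl on a carbon with a double bond to nitrogen. For the measured compounds named here, no measured step exchanges one substituent for another on this carbon, so the only guide is the flat picture of compounds 1, 2 and 3 and the unchanged step no change at the digits printed from compound 2 to compound 3 (within the scatter). A step within the scatter is therefore expected, no change at the digits printed from compound 3 to compound 4 (within the scatter), and compound 4 is estimated at 300 mg/kg, between 150 mg/kg and 600 mg/kg.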

Compound 4, minimum effective dose: 300 mg/kg
Compound 4: middle estimate and measured number agree at the digits printed, and the stated range covers the measured number.
By their numbers in this assay, from the lowest: compounds 1, 2, 3 and 4 (each within the scatter of the next).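

On this carbon, 4-methylphenyl takes the place of 3-hydroxyphenyl in this assay with a flat result (no change at the digits printed from compound 3 to compound 4 (within the scatter)), even though the hydrogen-bond donor and acceptor counted on the leaving group are absent from the entering one. The exchange on the amide-type nitrogen reads the same (no change at the digits printed from compound 2 to compound 4 (within the scatter)). No evidence is available that bears on this result.

The compounds shown leave open whether any group here can shift the minimum effective dose from this shared level. A carboxylic acid or a nitrile on the aromatic ring would test that.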